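Changing the Chain on Compound 3

The source may hold more compounds than are shown below. What is called first, only, known or untested is meant among the compounds shown, and "the series" means these compounds.

compound 1 `CCCCCCn1cnc2c(Nc3ccc(Cl)cc3)nc(N[C@H]3CC[C@H](N)CC3)nc21` gives 5500 nM
compound 2 `N[C@H]1CC[C@H](Nc2nc(Nc3ccc(Cl)cc3)c3ncn(C4CCCCC4)c3n2)CC1` gives 4100 nM
compound 3 `CC(C)=CCn1cnc2c(Nc3cccc(Cl)c3)nc(N[C@H]3CC[C@H](N)CC3)nc21` gives 7000 nM

All three compounds were tested in a functional assay on BT-474 cells (Homo sapiens) for inhibition, read by fluorescence, with a stated time of 72 h (a lower number here means a stronger inhibitor of growth, a higher number a weaker inhibitor of growth), and their values lie within the scatter of one another. Compound 3 at 7000 nM is therefore not set apart from compound 1 or compound 2 by this measure.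

Still unmeasured is compound 4 `CCCCn1cnc2c(Nc3cccc(Cl)c3)nc(N[C@H]3CC[C@H](N)CC3)nc21`. Going by the values given here, its change from compound 3 is propyl in place of 2-methylprop-1-en-1-yl on a saturated chain carbon bound to an aromatic nitrogen and no measured step makes this same change. The closest evidence is cyclohexyl in place of hexyl on an aromatic nitrogen, which gave a 1.3-fold lower number from compound 1 to compound 2 (0.13 log units; within the scatter) and so stayed within the scatter. Among the compounds with values here, with only that step to go on, no change beyond the scatter is expected in this assay for the new chain. The expected step is a 1.1-fold lower number from compound 3 to compound 4 (0.03 log units; within the scatter) and its direction is uncertain. Compound 4 is estimated at 6500 nM with 3200 nM to 13000 nM as its expected range.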

Compound 4, concentration for 50% growth inhibition: 5100 nM
Compound 4: middle estimate off by 1.3-fold (0.11 log units), on the high side; the measured number falls inside the stated range.
By their numbers in this assay, from the lowest: compounds 2, 4, 1 and 3 (each within the scatter of the next).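

In this assay, propyl in place of 2-methylprop-1-en-1-yl on a saturated chain carbon bound to an aromatic nitrogen gave a 1.4-fold lower number from compound 3 to compound 4 (0.14 log units; within the scatter). The earlier step, a 1.3-fold lower number from compound 1 to compound 2 (0.13 log units; within the scatter), set a ring against an open chain; this one shows that between two short chains, removing the double bond outside aromatic rings and one carbon leaves the number within the scatter at this position. No supporting measurement bears on this result.

The compounds shown leave open whether a chain carrying an amine or a carboxylic acid in this place would shift the number beyond the scatter in this assay. They also leave open whether a benzyl group here would do so.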